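Adding a Second Chloro to the Core of Compound 1

The compounds below may be only part of what the source reports. "The series", "measured", "known", "first", "only" and "open" are said of these compounds alone.

Among the compounds with values here, compound 1 `ClCc1ccccc1Cn1cnc2ncnc(Cl)c21` is the only member of this small set with a measured number. Within the data shown here, in a functional assay on SK-OV-3 cells (Homo sapiens) for cytotoxicity, read by sulforhodamine B assay, with a stated time of 48 h (a higher number here means a weaker inhibitor of growth, a lower number a stronger inhibitor of growth), compound 1 gives 26900 nM, which places it on its own, since the one other tested compound, compound 2 `ClCc1cccc(Cn2cnc3nc(Cl)nc(Cl)c32)c1`, has "not determined" (no result reported) in this assay. Compound 3 `ClCc1ccccc1Cn1cnc2nc(Cl)nc(Cl)c21` has not yet been measured. The change from compound 1 to compound 3 is chloro in place of hydrogen on an aromatic carbon; the new chloro sits on an aromatic carbon of the six-membered aromatic ring of the shared core, between two ring nitrogen atoms and meta to the chloro group already present. Among the measured compounds shown here, no pair of measured compounds shows this kind of step, so there is no measured guide to its size. The expectation is a small move toward stronger growth inhibition, at or near the edge of the usual scatter. The estimated step of a 1.5-fold lower number from compound 1 to compound 3 (0.17 log units; within the scatter) is therefore modest. Compound 3 is expected to give 18000 nM, with a range from 6000 nM to 55000 nM.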

Compound 3, concentration for total growth inhibition: 20900 nM
The estimate for compound 3 lay 1.2-fold (0.06 log units) below the measured number; the measured number falls inside the stated range.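

Within the data shown here, the first measured step for this change in this assay is a 1.3-fold lower number from compound 1 to compound 3 (0.11 log units; within the scatter) so compound 1 and compound 3 cannot be told apart in growth inhibition. At this aromatic carbon, between two ring nitrogen atoms, a chloro in place of hydrogen therefore leaves the reading within the ordinary variation between repeated measurements, and any real effect is too small to establish from this one pair. No measurement shown here explains this result.

This position is shown only with hydrogen and with chloro, so it remains open whether an amine, a methoxy group or a longer chain there would give a step beyond the scatter. Compound 2 has no result in this assay and so adds no comparison.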